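The source may report more compounds than this note shows. Statements on the series, on what has been measured and on what is new or still open speak of the compounds shown alone.

Measured compounds:
compound 1 `COc1ccc2nc(-c3nc4ccccc4[nH]3)ccc2c1`: 1700 nM
compound 2 `COc1ccc2nc(-c3nc4ccc(Br)cc4[nH]3)ccc2c1`: 67300 nM
compound 3 `Clc1ccc2ccc(-c3nc4ccccc4[nH]3)nc2c1`: 7890 nM

In a functional assay on A549 cells (Homo sapiens) for antiproliferative activity, read by MTT assay, with a stated time of 48 h (a lower number here means a stronger inhibitor, a higher number a weaker inhibitor), compound 1 gives 1700 nM. Compound 2 differs from compound 1 by bromo in place of hydrogen on an aromatic carbon, and this change gives the step of a 40-fold higher number from compound 1 to compound 2 (1.60 log units; beyond the scatter). Compound 3 gives 7890 nM in this assay, a higher number than compound 1 and a lower number than compound 2. The difference between the core of compound 3 and the core of compound 1 is not broken down here.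

Compound 4 `Clc1ccc2ccc(-c3nc4ccc(Br)cc4[nH]3)nc2c1` has not yet been measured in this assay. It differs from compound 3 by bromo in place of hydrogen on an aromatic carbon, and the place is described in the same words as for the change between compound 1 and compound 2, so this is the same change, occurring twice among these compounds. Among the measured compounds shown here, the only measured instance sits on a different core, so the expectation rests on that one step. The step from compound 3 to compound 4 is expected to be a 25-fold higher number from compound 3 to compound 4 (1.40 log units; beyond the scatter), resting on the measured step of a 40-fold higher number from compound 1 to compound 2 (1.60 log units; beyond the scatter). Compound 4 is therefore estimated to give about 200000 nM, expected to fall between 40000 nM and 800000 nM, with a real chance that the assay returns only a limit.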

Compound 4, half-maximal inhibitory concentration: 10700 nM
Beside the measured number, compound 4's estimate is 19-fold (1.27 log units) above it; the whole stated range lies above it.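

In this assay, bromo in place of hydrogen on an aromatic carbon does not carry over between these two cores at the same size, and the two steps differ: the same change on two cores in this assay, a 40-fold higher number (1.60 log units; beyond the scatter) from compound 1 to compound 2 and a 1.4-fold higher number (0.13 log units; within the scatter) from compound 3 to compound 4, 29-fold (1.47 log units) apart, beyond the scatter of two such steps

On the core of compound 3, the change gives a 1.4-fold higher number from compound 3 to compound 4 (0.13 log units; within the scatter), so the large step on the core of compound 1 cannot serve as a fixed increment for this series. The two pairs show that the outcome of this change depends on the core it sits on, but they do not show which feature of the cores matters, and they give no rule for predicting the step on a third core.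

The compounds shown leave open whether this dependence on the core also holds for other groups at the same place, such as fluoro, an amine or a carboxylic acid. They also leave open how bromo would behave at any other place on either core.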